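The source may report more compounds than this note shows. Statements on the series, on what has been measured and on what is new or still open speak of the compounds shown alone.

Compound 2 `CCOc1ccc(-c2c(NC(=O)c3ccc(OC(C)C)cc3)c(C(=O)O)nn2-c2ccc(Oc3ccccc3)cc2)cc1` gives the lowest of the two numbers measured in an assay for displacement of a labelled ligand from Apoptosis regulator Bcl-2 (Homo sapiens), read by fluorescence polarization, with a stated time of 30 min (on this read-out higher numbers stand for weaker inhibition and lower numbers for stronger inhibition), at 28 nM. Its nearest neighbour, compound 1 `CCOc1ccc(-c2c(NC(=O)c3ccccc3)c(C(=O)O)nn2-c2ccc(Oc3ccccc3)cc2)cc1`, gives 855 nM; the step of a 31-fold lower number from compound 1 to compound 2 (1.48 log units; beyond the scatter) came with isopropoxy in place of hydrogen on an aromatic carbon. Compound 3 `CCOc1ccc(-c2c(NC(=O)c3ccc(OCC(C)C)cc3)c(C(=O)O)nn2-c2ccc(Oc3ccccc3)cc2)cc1` differs from compound 2 by isobutyl in place of isopropyl on an oxygen on an aromatic ring. No measured step exchanges one alkyl group for another on that oxygen; the single step shown concerns adding the group rather than reshaping it. The expected step of a 1.1-fold higher number from compound 2 to compound 3 (0.03 log units; within the scatter) is therefore small and not beyond the scatter. Compound 3 is estimated at 30 nM, expected to fall between 10 nM and 90 nM.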

Compound 3, inhibition constant: 1040 nM
Compound 3: the middle estimate sits 35-fold (1.54 log units) below what was measured, outside the stated range (above it).
By their numbers in this assay, from the lowest: compound 2; then compounds 1 and 3 (each within the scatter of the next).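

Exchanging isopropyl for isobutyl on an oxygen on an aromatic ring gives a 37-fold higher number from compound 2 to compound 3 (1.57 log units; beyond the scatter) in this assay, so the benefit of the alkoxy group depends sharply on the exact alkyl group. Isobutoxy in place of hydrogen gives only a 1.2-fold higher number from compound 1 to compound 3 (0.09 log units; within the scatter) and so keeps none of the benefit seen with isopropoxy. Nothing available explains this sharp difference between two such similar groups.

From the compounds shown here alone, whether isopropoxy is unusual here or one of several good groups stays open. Methoxy, ethoxy, cyclopropyloxy and a tert-butoxy group would help to settle this.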